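A few compounds are considered here, and "the series" means these few. Any claim that something is new, unique, unknown or untested is made for them only; others in the source may bear on it.

Compound 1 `CCOC(=O)c1cnc(N2CCN(Cc3ccccc3C(F)(F)F)CC2)nc1Oc1c(C)cc(-c2ccc(C#N)cc2)cc1C` is one of three close relatives tested in an ADME assay on MT4 cells (Homo sapiens) for cytotoxicity, read by MTT assay, with a stated time of 4 days; on this read-out lower numbers stand for higher toxicity in this test and higher numbers for lower toxicity in this test. In this assay compound 1 reaches only a limit of the test, > 125000 nM. Compound 2 `CCOC(=O)c1cnc(N2CCN(Cc3cccc(Br)c3)CC2)nc1Oc1c(C)cc(-c2ccc(C#N)cc2)cc1C` likewise gives a limit, > 125000 nM. Compound 3 `CCOC(=O)c1cnc(N2CCN(Cc3ccccc3[N+](=O)[O-])CC2)nc1Oc1c(C)cc(-c2ccc(C#N)cc2)cc1C` also gives a limit, >= 78700 nM. All three values are limits, so the steps among them cannot be read: a step that the two limits leave unreadable from compound 1 to compound 2, a step that the two limits leave unreadable from compound 1 to compound 3 and a step that the two limits leave unreadable from compound 2 to compound 3. Two of the values sit at the limit of > 125000 nM in this assay, at which 2 of the 3 values shown sit, and one at the limit of >= 78700 nM in this assay, at which 1 of the 3 values shown sits. Compound 4 `CCOC(=O)c1cnc(N2CCN(Cc3cccc(C(N)=O)c3)CC2)nc1Oc1c(C)cc(-c2ccc(C#N)cc2)cc1C` differs from compound 1 by 3-carbamoylphenyl in place of 2-(trifluoromethyl)phenyl on a saturated chain carbon bound to an amine nitrogen in a ring. The nearest kin is the swap on the same saturated chain carbon from compound 1 to compound 2, yet its size stays unreadable. Compound 4 is therefore expected to show no readable step, a number no higher from compound 1 to compound 4 (the limit leaves the size open), with an estimated value of 125000 nM between 60000 nM and 250000 nM, most likely reported again as a limit.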

Compound 4, half-maximal cytotoxic concentration: 14800 nM
Compound 4: middle estimate off by 8.4-fold (0.93 log units), on the high side; the measured number lies below the stated range.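

For the compounds shown here, compound 4 is the first of these relatives to give a number rather than a limit in this assay, so the group on this saturated chain carbon can change the read-out. With 3-carbamoylphenyl in this place, toxicity in this test is higher than in all three relatives, with an at least 8.4-fold lower number from compound 1 to compound 4 (0.92 log units; beyond the scatter) and an at least 5.3-fold lower number from compound 3 to compound 4 (0.72 log units; beyond the scatter). The plainest case, carbamoyl in place of bromo on an aromatic carbon, gives an at least 8.4-fold lower number from compound 2 to compound 4 (0.92 log units; beyond the scatter).

The steps among compound 1, compound 2 and compound 3 still cannot be read, and nothing shown gives a cause for the drop. On these data alone, whether a carboxylic acid or an amine in place of the carbamoyl would also lower the number stays open.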